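Replacing a piperazine with a piperidine on the cyclohexyl amine

The source may report more compounds than this note shows. Statements on the series, on what has been measured and on what is new or still open speak of the compounds shown alone.

Among the measured compounds shown here, compound 2 `CN(C)C(=O)N1CCN([C@H]2CC[C@H](Nc3ncnc4[nH]cc(C5CCOCC5)c34)CC2)CC1` is the one compound here with a single number in an ADME assay on cells (Hepatocyte, Rattus norvegicus) for metabolic stability (a lower number here means slower removal, a higher number faster removal of the compound), where compound 2 gives 13 uL/min; one further entry for compound 2 reports no single number. For the measured compounds named here, compound 1 `CN(C)[C@H]1CC[C@H](Nc2ncnc3[nH]cc(C4CCCO4)c23)CC1` shares the core and, in this assay, compound 1 gives 59 uL/min; 36 uL/min (2 entries), the two entries standing within the usual scatter of each other (the several entries of compound 1 in this assay, 59 uL/min; 36 uL/min (2 entries)); no step between compound 1 and compound 2 is computed, since they differ in more than one place. Compound 3 `CN(C)C(=O)C1CCN([C@H]2CC[C@H](Nc3ncnc4[nH]cc(C5CCOCC5)c34)CC2)CC1` differs from compound 2 by one change: 4-(dimethylcarbamoyl)piperidin-1-yl in place of 4-(dimethylcarbamoyl)piperazin-1-yl on a saturated ring carbon. Going by the values given here, with no measured step between any two compounds, the step from compound 2 to compound 3 is expected to stay within the scatter, expected as a 1.2-fold higher number from compound 2 to compound 3 (0.06 log units; within the scatter). Compound 3 is therefore estimated at 15 uL/min in this assay, with a range from 7 uL/min to 32 uL/min.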

Compound 3, intrinsic clearance in a liver preparation (reported as CLH), per the amount of preparation that the assay uses in the Hepatocyte assay: 2 uL/min
Compound 3: middle estimate off by 7.5-fold (0.88 log units), on the high side; the whole stated range lies above it.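

In the Hepatocyte assay, 4-(dimethylcarbamoyl)piperidin-1-yl in place of 4-(dimethylcarbamoyl)piperazin-1-yl gives a 6.5-fold lower number from compound 2 to compound 3 (0.81 log units; beyond the scatter) on a saturated ring carbon, so changing one ring atom at this position is enough to move the number beyond the scatter. In a physicochemical assay for lipophilicity, using the shake flask method, at pH 7.4 (a lower number here means a more polar compound, a higher number a more lipophilic compound), compound 2 gives 1.5 and compound 3 gives -0.1 for the same exchange. Slower removal therefore accompanies a more polar compound in this pair, though a single pair cannot show that one follows from the other: the measured distribution coefficient of compound 2, 1.5, and of compound 3, -0.1, a number 1.60 log units lower (beyond the scatter).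

From the compounds shown here alone, it remains open whether the link between the two read-outs holds beyond this pair. Also open, going by these compounds, is whether a morpholine at this position, or a carboxylic acid in place of the dimethylcarbamoyl group, would give a similarly low number.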